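The compounds below may be only part of what the source reports. "The series", "measured", "known", "first", "only" and "open" are said of these compounds alone.

Measured compounds:
compound 1 `Cc1nc(S(C)(=O)=O)ccc1Oc1ncnc(OC2CCN(C(=O)OC(C)F)CC2)c1F` gives 68%
compound 2 `Cc1nc(S(C)(=O)=O)ccc1Oc1ncnc(OC2CCN(C(=O)OC3(C(F)(F)F)COC3)CC2)c1F` gives 84%
compound 3 `Cc1nc(S(C)(=O)=O)ccc1Oc1ncnc(OC2CCN(C(=O)SC(C)C)CC2)c1F` gives 81%

All three were tested in a functional assay on isolated protein for inhibition of Glucose-dependent insulinotropic receptor (Rattus norvegicus), read by HTRF and cAMP accumulation; on this read-out lower numbers stand for smaller maximal responses and higher numbers for larger maximal responses. Among them compound 1 stands lowest: compound 3 lies nearest, a number 13 percentage points higher from compound 1 to compound 3 (beyond the scatter), and compound 2 lies furthest, a number 16 percentage points higher from compound 1 to compound 2 (beyond the scatter). Compound 4 `Cc1nc(S(C)(=O)=O)ccc1Oc1ncnc(OC2CCN(C(=O)c3noc(C(C)(C)F)n3)CC2)c1F` has not yet been measured in this assay. It differs from compound 1 in one place: a group of 9 heavy atoms (5 carbon, 2 nitrogen, 1 oxygen, 1 fluorine; one five-membered aromatic ring with 3 hetero atoms) in place of a group of 4 heavy atoms (2 carbon, 1 oxygen, 1 fluorine; no ring), on a carbonyl carbon. Both measured steps that start from compound 1 bear on this change, since each of them also exchanges the group on the carbonyl carbon whose other neighbour is an amide-type nitrogen in a ring. Those two steps were modest and both went upward, and the two resulting compounds differ from each other only within the scatter. A step of similar size and direction is therefore expected for compound 4, namely a number 12 percentage points higher from compound 1 to compound 4 (beyond the scatter). The group that enters in compound 4 carries a ring, unlike either group tried so far, so the expectation rests on a loose analogy. Compound 4 is expected to give 80%, within a range from 68% to 92%.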

Compound 4, largest response reached (reported as efficacy), in percent of the reference or control that the assay uses: 74%
Compound 4: middle estimate off by 6 percentage points, on the high side; the range from low to high includes it.
By their numbers in this assay, from the lowest: compounds 1, 4, 3 and 2 (each within the scatter of the next, the first and the last beyond it).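

At the carbonyl carbon whose other neighbour is an amide-type nitrogen in a ring, a group with a five-membered aromatic ring with 3 hetero atoms leaves this assay within the scatter of all three earlier compounds: a number 6 percentage points higher from compound 1 to compound 4 (within the scatter), a number 7 percentage points lower from compound 3 to compound 4 (within the scatter) and a number 10 percentage points lower from compound 2 to compound 4 (within the scatter). Compound 2 also carries a ring in its 3-(trifluoromethyl)oxetan-3-yl group and stands beyond the scatter from compound 1, while compound 4 does not, so the presence of a ring in the entering group does not by itself settle the outcome at this position. Nothing measured here accounts for the difference between these groups.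

Going by these compounds, how a phenyl ring or a cyclopropyl group on this carbonyl carbon would read remains open. So does the outcome with a secondary amine there.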